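Propoxy for pentylamino on a shared purine-type core

The source may hold more compounds than are shown below. What is called first, only, known or untested is meant among the compounds shown, and "the series" means these compounds.

Compound 1 `COc1ccc(Cn2c(O)nc3c(N)ncnc32)cc1`: 10 uM
Compound 2 `CCCCCNc1nc(N)c2nc(O)n(Cc3ccccc3)c2n1`: 0.1 uM
Compound 3 `Nc1ncnc2c1nc(I)n2Cc1ccccc1`: > 10 uM

Of the compounds shown here, three have been tested in a functional assay (spleen, spleen) for activation, with Mus musculus as the target; on this read-out lower numbers stand for an effect already at smaller amounts and higher numbers for an effect only at larger amounts of compound. Compound 2 stands at the lowest of the two numbers given; in this assay compound 1 gives 10 uM, and the gap between them lies beyond the scatter. Compound 3 gives only a limit of the assay, > 10 uM, and no number (the limit of > 10 uM in this assay, at which 1 of the 3 values shown sits).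

Compound 4 `CCCOc1nc(N)c2nc(O)n(Cc3ccccc3)c2n1` has not yet been measured. It differs from compound 2 in one place: propoxy in place of pentylamino on an aromatic carbon. Among the compounds with values here, no step between measured compounds covers this exchange, so the expectation rests on compound 2 alone. With its value of 0.1 uM, compound 2 sets the starting point, and the step from it to compound 4 is expected to be small, within or close to the scatter, in either direction no change at the digits printed from compound 2 to compound 4 (within the scatter). Compound 4 is thus estimated at 0.1 uM, with a range from 0.01 uM to 1 uM.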

Compound 4, minimum effective concentration: 0.01 uM
The estimate for compound 4 lay 10-fold (1.00 log units) above the measured number, and the stated range covers the measured number.
By their numbers in this assay, from the lowest: compound 4; then compound 2; then compound 1.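

In this assay, the aromatic carbon between two ring nitrogen atoms proves sensitive to the group it carries: propoxy in place of pentylamino gives a 10-fold lower number from compound 2 to compound 4 (1.00 log units; beyond the scatter). The exchange removes the hydrogen-bond donor counted on pentylamino, so that donor is not needed for an effect at these small amounts of compound in this series. No measurement shown here gives a reason for the step.

The compounds shown leave open whether the step follows the change from the nitrogen to the oxygen link or the change in chain length, as both change together. Propylamino or pentyloxy on this carbon would separate the two, and butoxy or a longer alkoxy chain would show how far the trend runs.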